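Adding a Chlorine to the Anilino Ring

The source may report more compounds than this note shows. Statements on the series, on what has been measured and on what is new or still open speak of the compounds shown alone.

Of the compounds shown here, two that share one core have been tested in a functional assay on PC-3 cells (Homo sapiens) for cytotoxicity, read by MTT assay, with a stated time of 72 h; on this read-out lower numbers stand for stronger inhibition and higher numbers for weaker inhibition. Compound 2 `FC(F)(F)c1ccc(CSc2nc(Nc3ccccc3)c3ccccc3n2)cc1` gives 20000 nM. Compound 1 `CCCCCCCCCCCCNc1nc(SCc2ccc(C(F)(F)F)cc2)nc2ccccc12` gives 26000 nM. Compound 2 has the lower of the two numbers, but its gap to compound 1 is within the scatter, so the two cannot be told apart on these data. Compound 3 `FC(F)(F)c1ccc(CSc2nc(Nc3cccc(Cl)c3)c3ccccc3n2)cc1` has not yet been measured. It differs from compound 2 by chloro in place of hydrogen on an aromatic carbon. For the measured compounds named here, no measured pair shows what such a change does, so the expectation rests on the change alone: a small step, somewhat more likely toward a lower number than a higher one, and probably not beyond the scatter. Compound 3 is therefore expected to give 15000 nM, within a range from 6000 nM to 40000 nM. The estimated step, a 1.3-fold lower number from compound 2 to compound 3 (0.12 log units; within the scatter), is expected to stay inside the usual scatter.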

Compound 3, half-maximal inhibitory concentration: 13400 nM
Estimate against measurement, compound 3: 1.1-fold (0.05 log units) above; the measured number falls inside the stated range.
By their numbers in this assay, from the lowest: compounds 3, 2 and 1 (each within the scatter of the next).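

For the compounds shown here, this is the first pair that differs in only one place, so a single substitution on the anilino ring can now be read directly in this assay. Chloro in place of hydrogen on this aromatic carbon gives a 1.5-fold lower number from compound 2 to compound 3 (0.17 log units; within the scatter), so a ring carrying this chlorine cannot be told apart from the bare ring on these data. Nothing available explains the size of this step.

One pair cannot show whether chloro would behave the same way on another carbon of this ring. It also leaves open what a different group at this position, such as a methoxy group, an amine or a carboxylic acid, would do to the number.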